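From 2-cyanobenzyl to 3-chlorobenzyl on the shared core

This account rests on a few compounds, and the source may have more. Where it says the series, first, only, none or still open, it means among the compounds named here.

In a functional assay on HepG2 cells (Homo sapiens) for antiproliferative activity, read by MTT assay, with a stated time of 24 h (a lower number here means a stronger inhibitor, a higher number a weaker inhibitor), compound 1 `C#CCOc1ccc2c(=O)c(-c3cc(OC)c(OC)cc3OC)coc2c1` gives 4950 nM. Compound 2 `COc1cc(OC)c(-c2coc3cc(OCc4ccccc4C#N)ccc3c2=O)cc1OC` reads > 10000 nM, which is a limit of the assay and not a number. It therefore stands at the limit of > 10000 nM in this assay, at which 1 of the 2 values shown sits.

Compound 3 `COc1cc(OC)c(-c2coc3cc(OCc4cccc(Cl)c4)ccc3c2=O)cc1OC` carries 3-chlorophenyl in place of 2-cyanophenyl on a saturated chain carbon bound to an oxygen on an aromatic ring.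

For the measured compounds named here, one measured step bears on this place: an at least 2.0-fold higher number from compound 1 to compound 2 (0.30 log units; that floor lies within the scatter). Going by the values given here, it gives only a floor, and no measured step exchanges one substituted phenyl for another. Among the compounds with values here, with compound 1 at 4950 nM as the only number nearby, a modest shift to a lower number in this assay is expected, with low confidence: an at least 1.2-fold lower number from compound 2 to compound 3 (0.09 log units; that floor lies within the scatter). A second limit would not surprise. For compound 3 the estimated value is 8000 nM, with an expected range of 2500 nM to 20000 nM.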

Compound 3, half-maximal inhibitory concentration: 750 nM
Compound 3: the middle estimate sits 11-fold (1.03 log units) above what was measured, and the stated range ends above it.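

At this place, on a saturated chain carbon bound to an oxygen on an aromatic ring, the choice of substituted phenyl strongly shifts the read-out in this assay: 3-chlorophenyl in place of 2-cyanophenyl gives an at least 13-fold lower number from compound 2 to compound 3 (1.12 log units; beyond the scatter). Compound 2 reads > 10000 nM, which is a limit of the assay and not a number, and the size of that step is therefore only a floor: the limit of > 10000 nM in this assay, at which 1 of the 3 values shown sits. A phenyl-bearing group at this place can also outperform the small ethynyl group, with 3-chlorophenyl in place of ethynyl giving a 6.6-fold lower number from compound 1 to compound 3 (0.82 log units; beyond the scatter).

For the compounds shown here, the one step changes both the substituent and its ring position, leaving open which of the two accounts for the shift. As far as these compounds go, how an unsubstituted benzyl group or a longer chain ending in an amine would read at this place also remains open.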